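The source may hold more compounds than are shown below. What is called first, only, known or untested is meant among the compounds shown, and "the series" means these compounds.

Compound 2 `Clc1ccc(Cn2cc(CCCOc3cccc4cccnc34)nn2)cc1` holds the lowest number of the three compounds measured in a functional assay on PC-3 cells (Homo sapiens) for inhibition, read by sulforhodamine B assay, with a stated time of 48 h (a higher number here means a weaker inhibitor of growth, a lower number a stronger inhibitor of growth), where compound 2 gives 3.6 ug/mL. Compound 1 `Fc1ccc(Cn2cc(CCCOc3cccc4cccnc34)nn2)cc1` gives 20.1 ug/mL and compound 3 `FC(F)(F)Oc1ccc(Cn2cc(CCCOc3cccc4cccnc34)nn2)cc1` gives 5 ug/mL; the steps of a 5.6-fold lower number from compound 1 to compound 2 (0.75 log units; beyond the scatter) and a 4.0-fold lower number from compound 1 to compound 3 (0.60 log units; beyond the scatter) lie beyond the scatter, whereas a 1.4-fold higher number from compound 2 to compound 3 (0.14 log units; within the scatter) does not. Compound 4 `Clc1cc(Cl)c(Cn2cc(CCCOc3cccc4cccnc34)nn2)c(Cl)c1` differs from compound 2 by 2,4,6-trichlorophenyl in place of 4-chlorophenyl on a saturated chain carbon bound to an aromatic nitrogen. Among the compounds with values here, only a 5.6-fold lower number from compound 1 to compound 2 (0.75 log units; beyond the scatter), chloro in place of fluoro on an aromatic carbon, bears on this change, and no measured pair shows two further chlorines on that ring; the step to compound 4 in this assay is therefore expected to be small, in either direction, or none beyond the scatter. Compound 4 is estimated at 3 ug/mL, within 1 ug/mL to 9 ug/mL, an expected step of a 1.2-fold lower number from compound 2 to compound 4 (0.08 log units; within the scatter).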

Compound 4, concentration for 50% growth inhibition: 2.8 ug/mL
Compound 4: the middle estimate sits 1.1-fold (0.03 log units) above what was measured; the measured number falls inside the stated range.
By their numbers in this assay, from the lowest: compounds 4, 2 and 3 (each within the scatter of the next); then compound 1.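

Within the data shown here, on the saturated chain carbon bound to an aromatic nitrogen, 2,4,6-trichlorophenyl reads the same as 4-chlorophenyl in this assay (a 1.3-fold lower number from compound 2 to compound 4 (0.11 log units; within the scatter)), so the two further chlorines on that ring, which no earlier pair covered, bring no change beyond the scatter. The gap to the 4-fluorophenyl compound stays beyond the scatter (a 7.2-fold lower number from compound 1 to compound 4 (0.86 log units; beyond the scatter)), as it did for compound 2. Nothing available here explains either result. From the compounds shown here alone, what an amine or a carboxylic acid on that ring would give remains open, as does a longer chain at this place.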